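The source may hold more compounds than are shown below. What is called first, only, known or untested is meant among the compounds shown, and "the series" means these compounds.

Measured in a functional assay on CCRF-CEM cells (Homo sapiens), read by MTT assay, with a stated time of 72 h; a higher number here means a weaker inhibitor, a lower number a stronger inhibitor:
- compound 1 `C#Cc1cn([C@@H]2O[C@H](CO)[C@@H](O)[C@H]2O)c2ncnc(OC)c12`: > 20000 nM, a limit
- compound 2 `CSc1ncnc2c1c(-c1cccs1)cn2[C@@H]1O[C@H](CO)[C@@H](O)[C@H]1O`: > 20000 nM, a limit
- compound 3 `CNc1ncnc2c1c(-c1ccco1)cn2[C@@H]1O[C@H](CO)[C@@H](O)[C@H]1O`: 180 nM

Going by the values given here, compound 3 holds the only true number in this small set. The other two entries are not numbers: the limit of > 20000 nM in this assay, at which 2 of the 3 values shown sit. Among the compounds with values here, neither compound 1 nor compound 2 differs from compound 3 in one place only, so no measured step is available for comparison.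

The next compound is compound 4 `CNc1ncnc2c1c(-c1ccccc1)cn2[C@@H]1O[C@H](CO)[C@@H](O)[C@H]1O`, with phenyl in place of furan-2-yl on an aromatic carbon of the five-membered aromatic ring of the shared core: phenyl in place of furan-2-yl on an aromatic carbon. The methylamino side of compound 3 stays as it is.

Within the data shown here, no measured pair covers this exchange, so the expectation is weakly grounded. It rests on the fact that, among the compounds tested in this assay, only compound 3 reaches a number, at 180 nM. A clear loss of potency, beyond the scatter, is expected. The estimated step is a 22-fold higher number from compound 3 to compound 4 (1.35 log units; beyond the scatter), toward weaker inhibition. A result reported only as a limit is also a real possibility. For compound 4 the expected value is 4000 nM, with an estimated range from 500 nM to 20000 nM.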

Compound 4, half-maximal inhibitory concentration: > 20000 nM
Compound 4: a limit, no number; the forecaster's own chance of this, stated with the estimate: 35%; at least 5.0-fold (0.69 log units) between middle value and limit.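

In this assay, going by these compounds alone, the exchange of furan-2-yl for phenyl on an aromatic carbon of the five-membered aromatic ring gives an at least 110-fold higher number from compound 3 to compound 4 (2.04 log units; beyond the scatter), the first measured step. Within the data shown here, with the methylamino side unchanged, this one position alone separates the only compound with a true number from a compound reported as a limit, so the series does not tolerate every aromatic ring at this carbon. Compound 4 joins the compounds at the limit, so the step gives only a floor and its true size stays unknown: the limit of > 20000 nM in this assay, at which 3 of the 4 values shown sit.

The exchange changes ring size and removes the ring oxygen at once, so these data cannot say which of the two differences matters, and compounds 1 and 2 cannot help, as each differs from compound 3 in more than one place. Open questions are whether furan-3-yl or pyrrol-2-yl at this carbon would keep a measurable value in this assay, and whether furan-2-yl would do so with a methoxy or methylsulfanyl group in place of the methylamino side.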